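The source may report more compounds than this note shows. Statements on the series, on what has been measured and on what is new or still open speak of the compounds shown alone.

Measured compounds:

compound 1, `CN(C)CCCNc1nc(-c2ccc(NC(=O)Nc3ccc(Cl)cc3)cc2)nc2c(Cl)c(Cl)sc12`, in a functional assay on HT-29 cells (Homo sapiens) for cytotoxicity, read by MTT assay, with a stated time of 72 h (on this read-out higher numbers stand for weaker inhibition and lower numbers for stronger inhibition), compound 1 gives 330 nM
compound 2, `CN(C)CCCNc1nc(-c2ccc(NC(=O)Nc3ccccc3Cl)cc2)nc2c(Cl)c(Cl)sc12`, in this assay compound 2 gives 820 nM
compound 3, `CN(C)CCNc1nc(-c2ccc(NC(=O)Nc3ccc(Cl)cc3)cc2)nc2ccsc12`, in this assay compound 3 gives 95 nM

Compound 3 gives the lowest number of the three measured; its gaps to compound 1 and to compound 2 are both beyond the scatter. The difference between the core of compound 3 and the core of compound 1 is not broken down here.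

Within the core of compound 1, the change 2-chlorophenyl in place of 4-chlorophenyl on an amide-type nitrogen gave a 2.5-fold higher number from compound 1 to compound 2 (0.40 log units; beyond the scatter).

Compound 4, `CN(C)CCNc1nc(-c2ccc(NC(=O)Nc3ccccc3Cl)cc2)nc2ccsc12`, is not yet measured. It differs from compound 3 by 2-chlorophenyl in place of 4-chlorophenyl on an amide-type nitrogen, the same change, made at the same place. The step is expected to be similar in size, a 2.5-fold higher number from compound 3 to compound 4 (0.40 log units; beyond the scatter), because compound 1 to compound 2 gave a 2.5-fold higher number from compound 1 to compound 2 (0.40 log units; beyond the scatter). Compound 4 is therefore estimated at 240 nM in this assay, expected to fall between 120 nM and 600 nM.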

Compound 4, half-maximal inhibitory concentration: 310 nM
Beside the measured number, compound 4's estimate is 1.3-fold (0.11 log units) below it, and the stated range covers the measured number.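

In this assay, 2-chlorophenyl in place of 4-chlorophenyl on an amide-type nitrogen gives a 3.3-fold higher number from compound 3 to compound 4 (0.51 log units; beyond the scatter), and the two cores shown agree on the direction and size of this step: the same change on two cores in this assay, a 2.5-fold higher number (0.40 log units; beyond the scatter) from compound 1 to compound 2 and a 3.3-fold higher number (0.51 log units; beyond the scatter) from compound 3 to compound 4, 1.3-fold (0.12 log units) apart, within the scatter of two such steps

The change therefore carries over between the core of compound 1 and the core of compound 3. Two pairs in a single cell assay do not establish that it holds across the series, and they give no explanation for the step.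

As far as these compounds go, it remains open how an unsubstituted phenyl or a methoxyphenyl on the same nitrogen would compare with either chlorophenyl. Also open, from the compounds shown here alone, is whether the step persists with a morpholine in place of the dimethylamino group.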